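Hydroxy to methyl: estimate for compound 3

The source may report more compounds than this note shows. Statements on the series, on what has been measured and on what is new or still open speak of the compounds shown alone.

In a functional assay on HL-60 cells (Homo sapiens) for cytotoxicity, read by WST assay, with a stated time of 48 h (on this read-out higher numbers stand for an effect only at larger amounts of compound and lower numbers for an effect already at smaller amounts), compound 1 `Cc1ccccc1C[C@H]1COC(=O)[C@@H]1Cc1ccc(Cl)c(Cl)c1` gives 22000 nM. Compound 2 `O=C1OC[C@H](Cc2ccc(O)cc2)[C@H]1Cc1ccc(Cl)c(Cl)c1` gives 37000 nM, which lies within the scatter of compound 1. Compound 3 `Cc1ccc(C[C@H]2COC(=O)[C@@H]2Cc2ccc(Cl)c(Cl)c2)cc1` has methyl in place of hydroxy on an aromatic carbon, para to a large group (methyl in place of hydroxy on an aromatic carbon). Going by the values given here, the only measured step that bears on this change is a 1.7-fold higher number from compound 1 to compound 2 (0.23 log units; within the scatter), so no step beyond the scatter is expected in this assay. The estimated step is a 1.5-fold lower number from compound 2 to compound 3 (0.17 log units; within the scatter). For compound 3 the expected value is 25000 nM, with an estimated range of 10000 nM to 60000 nM.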

Compound 3, half-maximal effective concentration: 19000 nM
Estimate against measurement, compound 3: 1.3-fold (0.12 log units) above; measured number inside the range.
By their numbers in this assay, from the lowest: compounds 3, 1 and 2 (each within the scatter of the next).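

Methyl in place of hydroxy on an aromatic carbon, para to a large group, gives a 1.9-fold lower number from compound 2 to compound 3 (0.29 log units; within the scatter) in this assay and so shows that losing the hydroxy hydrogen-bond donor and acceptor at this place brings no step beyond the scatter. 4-Methylphenyl in place of 2-methylphenyl gives a 1.2-fold lower number from compound 1 to compound 3 (0.06 log units; within the scatter) and so the methyl, in either placing, also brings no such step. No measurement on these compounds offers a cause for either result.

Going by these compounds, whether an amine or a carboxylic acid on this aromatic carbon, or a longer chain in place of methyl, would give a step beyond the scatter stays open.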